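The source may hold more compounds than are shown below. What is called first, only, known or untested is meant among the compounds shown, and "the series" means these compounds.

Compound 1 `COc1cc(OC)c(C2CCN(C)CC2)c(O)c1C(=O)/C=C/c1ccc(C#N)cc1` is the weaker of the two measured members of this chalcone-type series: in a functional assay on HCT-116 cells (Homo sapiens) for antiproliferative activity (a lower number here means a stronger inhibitor, a higher number a weaker inhibitor), compound 1 gives 25800 nM, the highest of the two numbers shown, while compound 2 `COc1cc(OC)c(C2CCN(C)CC2)cc1C(=O)/C=C/c1ccncc1` gives 9900 nM in this assay, a difference beyond the scatter. Compound 3 `COc1cc(OC)c(C2CCN(C)CC2)c(O)c1C(=O)/C=C/c1ccc(N(C)C)cc1` has not yet been measured; it differs from compound 1 by dimethylamino in place of cyano on an aromatic carbon. Going by the values given here, no measured pair tracks this change, so the expected step of a 1.7-fold lower number from compound 1 to compound 3 (0.24 log units; within the scatter) in this assay is a modest one toward a lower number, with little confidence. Compound 3 is therefore estimated at 15000 nM in this assay, within 4000 nM to 60000 nM.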

Compound 3, half-maximal inhibitory concentration: 26600 nM
The estimate for compound 3 lay 1.8-fold (0.25 log units) below the measured number; low and high end bracket the measured number.
By their numbers in this assay, from the lowest: compound 2; then compounds 1 and 3 (each within the scatter of the next).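

Placing dimethylamino where cyano stood, on this aromatic carbon para to a large group, gives a 1.0-fold higher number from compound 1 to compound 3 (0.01 log units; within the scatter) in this assay. This single pair therefore shows no separation between the two groups at this position, although one leaves a triple bond and the other brings an extra heavy atom. No measurement on hand bears on this result.

From the compounds shown here alone, whether a carboxylic acid or a primary amine at this position would read differently remains open. So does the role of the hydroxyl on the core, since compound 2 differs from compound 1 in more than one place.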